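A few compounds are considered here, and "the series" means these few. Any claim that something is new, unique, unknown or untested is made for them only; others in the source may bear on it.

Measured compounds in an in vivo ADME assay on the whole organism (strain Wistar) for pharmacokinetics, with Rattus norvegicus as the target, at a dose of 4 mg/kg by the oral route; on this read-out higher numbers stand for higher exposure at the dose given and lower numbers for lower exposure:
compound 1 `C=C[C@@H]1C[C@]1(NC(=O)[C@@H]1C[C@@H]2CN1C(=O)[C@H](C1CCCCC1)CC(=O)NCCCCCc1cccc3c1CN(C3)C(=O)O2)C(=O)NS(=O)(=O)C1CC1` gives 80 nM
compound 2 `C=C[C@@H]1C[C@]1(NC(=O)[C@@H]1C[C@@H]2CN1C(=O)[C@H](C1CCCCC1)CC(=O)NCCCCCc1cc(OC)cc3nc(-c4ccccc4)cc(c13)O2)C(=O)NS(=O)(=O)C1CC1` gives "below limit of detection" (no number reported)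

Compound 1 and compound 2 share a large core and differ in the ring system that closes the macrocycle. In this assay compound 1 reaches 80 nM. Going by the values given here, for compound 2 this assay reports "below limit of detection" (no number reported), so no number stands for compound 2 and no sized step can be given between compound 1 and compound 2; the two read-outs show only that compound 2 falls where the assay no longer returns a value.

Compound 3 `C=C[C@@H]1C[C@]1(NC(=O)[C@@H]1C[C@@H]2CN1C(=O)[C@H](C1CCCCC1)CC(=O)N(C(C)C)CCCCCc1cc(OC)cc3nc(-c4ccccc4)cc(c13)O2)C(=O)NS(=O)(=O)C1CC1` carries the change (isopropyl in place of hydrogen on an amide-type nitrogen in a ring). Among the compounds with values here, no step of this kind has been measured among the compounds here. The direction and size of its effect in this assay are therefore open. A move from an undetected level to a measurable one would be needed for compound 3 to register at all, and the account can only say that an increase beyond the scatter is possible while a repeat of the undetected outcome is equally plausible. Compound 3 is therefore expected to give about 25 nM, within a wide range from 3 nM to 250 nM.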

Compound 3, maximal plasma concentration: 380 nM
Beside the measured number, compound 3's estimate is 15-fold (1.18 log units) below it, outside the stated range (above it).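

Compound 2 has no number in this assay and no sized step can be read from it to compound 3. The compounds shown leave open how large the effect of isopropyl in place of hydrogen on the amide-type nitrogen is, and whether it would carry over to other cores. Nothing shown here offers an explanation for the result.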